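This account rests on a few compounds, and the source may have more. Where it says the series, first, only, none or still open, it means among the compounds named here.

Working notes on ether variants of the shared core. In a functional assay on MCF7 cells (Homo sapiens) for antiproliferative activity, read by MTT assay, with a stated time of 48 h (a higher number here means a weaker inhibitor, a lower number a stronger inhibitor), compound 1 (`CCOc1cc(-c2ccc3[nH]ccc3c2)cn2c(-c3cc(OC)c(OC)c(OC)c3)nnc12`) gives 284 nM, compound 2 (`COc1cc(-c2nnc3c(OC(C)C)cc(-c4ccc5[nH]ccc5c4)cn23)cc(OC)c1OC`) gives 1020 nM and compound 3 (`COc1cc(-c2nnc3c(OCC(F)(F)F)cc(-c4ccc5[nH]ccc5c4)cn23)cc(OC)c1OC`) gives 608 nM. Compound 2 is separated from compound 1 but not from compound 3: the steps are a 3.6-fold higher number from compound 1 to compound 2 (0.56 log units; beyond the scatter) and a 1.7-fold lower number from compound 2 to compound 3 (0.22 log units; within the scatter). The remaining step is a 2.1-fold higher number from compound 1 to compound 3 (0.33 log units; beyond the scatter).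

Compound 4 (`COc1cc(-c2nnc3c(OC4CN(C(C)(C)C)C4)cc(-c4ccc5[nH]ccc5c4)cn23)cc(OC)c1OC`) replaces the isopropoxy of compound 2 with (1-(tert-butyl)azetidin-3-yl)oxy: 1-(tert-butyl)azetidin-3-yl in place of isopropyl on an oxygen on an aromatic ring. All three measured steps change the group on this same oxygen, so they bear on the new change. They are modest or lie within the scatter. None of them introduces a ring or a nitrogen, so the data offer only a loose guide to this larger group. On these data alone, no step beyond the scatter is therefore expected in this assay, and the direction remains open. The expected step is a 1.3-fold higher number from compound 2 to compound 4 (0.11 log units; within the scatter). For compound 4 the estimated value is 1300 nM, with an expected range of 350 nM to 4500 nM.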

Compound 4, half-maximal inhibitory concentration: > 10000 nM
Compound 4 gave a limit, no number; the forecaster's own chance of this, stated with the estimate: 3%; middle value at least 7.6-fold (0.88 log units) from the limit.
By their numbers in this assay, from the lowest: compound 1; then compounds 3 and 2 (each within the scatter of the next). At a limit, above all of these: compound 4.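

With the (1-(tert-butyl)azetidin-3-yl)oxy group on this oxygen, the group here turns out to matter far more in this assay than the ethyl, isopropyl and 2,2,2-trifluoroethyl ethers suggested. Measured against those three, the change reads as (an at least 9.8-fold higher number from compound 2 to compound 4 (0.99 log units; beyond the scatter)) and (an at least 16-fold higher number from compound 3 to compound 4 (1.21 log units; beyond the scatter)) and (an at least 35-fold higher number from compound 1 to compound 4 (1.54 log units; beyond the scatter)), each beyond the scatter, so the position does not accept every larger group on the oxygen. The reading for compound 4 is a limit of the assay, not a number, so the true size of these steps stays unknown: the limit of > 10000 nM in this assay, at which 1 of the 4 values shown sits.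

The nitrogen, the four-membered ring and the tert-butyl all enter in one step, and the compounds shown leave open which of them goes with the weaker reading. A cyclobutyl group on the same oxygen, or an azetidin-3-yl carrying methyl in place of tert-butyl, would separate these parts.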